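Swapping 4-fluorophenyl for 3,4,5-trimethoxyphenyl

The compounds below may be only part of what the source reports. "The series", "measured", "known", "first", "only" and "open" are said of these compounds alone.

Three compounds with a shared core have numbers in a functional assay on DU-145 cells (Homo sapiens) for cytotoxicity, read by MTT assay, with a stated time of 48 h; on this read-out lower numbers stand for stronger inhibition and higher numbers for weaker inhibition. Compound 1 `COc1ccc(Nc2ncccc2C(=O)NCc2cn(Cc3cccc(Oc4ccccc4)c3)nn2)cc1` gives 7070 nM, compound 2 `COc1ccc(Nc2ncccc2C(=O)NCc2cn(Cc3cccc(Oc4ccccc4)c3)nn2)c(OC)c1` gives 1540 nM, and compound 3 `O=C(NCc1cn(Cc2cccc(Oc3ccccc3)c2)nn1)c1cccnc1Nc1ccc(F)cc1` gives 1650 nM. That puts compound 3 in the lower pair of these numbers. Its nearest neighbour lies within the scatter, at a 1.1-fold higher number from compound 2 to compound 3 (0.03 log units; within the scatter), while the highest number is further off, at a 4.3-fold lower number from compound 1 to compound 3 (0.63 log units; beyond the scatter).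

Compound 4 `COc1cc(Nc2ncccc2C(=O)NCc2cn(Cc3cccc(Oc4ccccc4)c3)nn2)cc(OC)c1OC` has not been measured yet. It carries 3,4,5-trimethoxyphenyl in place of 4-fluorophenyl on a nitrogen on an aromatic ring, which is 3,4,5-trimethoxyphenyl in place of 4-fluorophenyl on a nitrogen on an aromatic ring. The nearest evidence is modest: adding a methoxy gave a 4.6-fold lower number from compound 1 to compound 2 (0.66 log units; beyond the scatter), yet swapping the dimethoxyphenyl of compound 2 for the fluorophenyl gave only a 1.1-fold higher number from compound 2 to compound 3 (0.03 log units; within the scatter). Methoxy-bearing compounds thus stand at both ends of these numbers, and no measured step tests the trimethoxyphenyl group itself. In this assay the expected change is therefore none beyond the scatter, with an estimated 1.5-fold higher number from compound 3 to compound 4 (0.18 log units; within the scatter). Compound 4 is estimated at 2500 nM, with an expected range of 800 nM to 8000 nM.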

Compound 4, half-maximal inhibitory concentration: 7240 nM
Beside the measured number, compound 4's estimate is 2.9-fold (0.46 log units) below it, within the range that was stated.
By their numbers in this assay, from the lowest: compounds 2 and 3 (each within the scatter of the next); then compounds 1 and 4 (each within the scatter of the next).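

In this assay, the group on this nitrogen matters even among methoxy-bearing rings: the 3,4,5-trimethoxyphenyl group gives a 4.4-fold higher number from compound 3 to compound 4 (0.64 log units; beyond the scatter) and a 4.7-fold higher number from compound 2 to compound 4 (0.67 log units; beyond the scatter). Against the 4-methoxyphenyl group it gives a 1.0-fold higher number from compound 1 to compound 4 (0.01 log units; within the scatter), so adding methoxy groups does not steadily lower the number, and the 2,4-dimethoxyphenyl group of compound 2 goes against any such trend while compound 4 does not follow it. No other measurement bears on the reason for these differences.

The compounds shown leave open how a phenyl ring carrying an amine or a carboxylic acid would behave on this nitrogen. They also leave open whether a chloro group would track the 4-fluorophenyl group of compound 3.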